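The compounds below may be only part of what the source reports. "The series", "measured", "known", "first", "only" and "open" are said of these compounds alone.

Working notes on the series. In a functional assay on OVCAR-5 cells (Homo sapiens) for inhibition (on this read-out higher numbers stand for weaker inhibition of growth and lower numbers for stronger inhibition of growth), compound 1 (`Nc1ccc(-c2nc3ccc(F)cc3s2)cc1Cl`) gives 70 nM. Within the data shown here, this is the lower of the two numbers so far and lies beyond the scatter from compound 2 (`Cc1cc(-c2nc3cccc(F)c3s2)ccc1N`), which gives 1300 nM. Compound 1 therefore sets the mark for the next comparison.

Compound 3 (`Cc1cc(-c2nc3ccc(F)cc3s2)ccc1N`) has not yet been measured. Relative to compound 1, the change is methyl in place of chloro on an aromatic carbon, ortho to an amino group and meta to a large group. The rest of the structure stays the same.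

Compounds 1 and 2 differ in more than one place, so the data give no measured size for this exchange. With no evidence favouring either direction, no step beyond the scatter is expected in this assay, and the starting point is compound 1 at 70 nM. This is a weakly supported expectation, so the range is kept wide. The expected change is a 1.2-fold lower number from compound 1 to compound 3 (0.07 log units; within the scatter). For compound 3, the estimated value is 60 nM, with an expected range of 10 nM to 350 nM.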

Compound 3, concentration for 50% growth inhibition: > 100000 nM
Compound 3: a limit, no number; the forecaster's own chance of this, stated with the estimate: 5%; at least 1600-fold (3.22 log units) between middle value and limit.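

Among these compounds, the exchange of chloro for methyl on an aromatic carbon, ortho to an amino group and meta to a large group, is the first single-place comparison, and it gives an at least 1400-fold higher number from compound 1 to compound 3 (3.15 log units; beyond the scatter). This shows that the position is far from indifferent to the exchange, even though the two groups count the same number of heavy atoms and neither carries a hydrogen-bond donor, acceptor or net charge. In this assay compound 3 gives > 100000 nM, which is a limit of the assay and not a number, so the step has a lower bound but no fixed size: the limit of > 100000 nM in this assay, at which 1 of the 3 values shown sits.

The compounds shown leave open whether hydrogen, bromo, trifluoromethyl or methoxy on this carbon would read close to compound 1 or close to compound 3, and therefore whether chloro is unusually favourable here or methyl is unusually poor. Among the compounds shown here, the reason for the step also stays open, as the data hold no measured property of either group and only this one pair for the exchange.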